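The source may report more compounds than this note shows. Statements on the series, on what has been measured and on what is new or still open speak of the compounds shown alone.

Measured in an assay for inhibition of 15-hydroxyprostaglandin dehydrogenase [NAD(+)] (Homo sapiens), read by fluorescence, with a stated time of 15 min, in the presence of a further agent that is not named here (on this read-out lower numbers stand for stronger inhibition and higher numbers for weaker inhibition), so far:

Compound 1 `CCC[S+]([O-])c1sc2nc(-c3cccs3)cc(C(=O)O)c2c1N`: 71 nM
Compound 2 `CCCC[S+]([O-])c1sc2nc(-c3nccs3)cc(-c3ccc(C(=O)N(C)C)cc3)c2c1N`: 5.9 nM
Compound 3 `CCCC[S+]([O-])c1sc2nc(-c3nccs3)cc(-c3cnc(Cl)n3C)c2c1N`: 3.2 nM

Compound 2 stands second highest of the three numbers. Its nearest neighbour is compound 3, whose number is lower by a margin that lies within the scatter, so no order between compound 2 and compound 3 is claimed. Within the data shown here, the furthest is compound 1, whose number is higher by a margin beyond the scatter; compound 1 differs from compound 2 in several places at once, and no single step between them is recorded, so only the two values themselves are noted.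

Compound 4 `CCCC[S+]([O-])c1sc2nc(-c3nccs3)cc(-c3ccc(COC(=O)NCC)cc3)c2c1N` awaits measurement. It differs from compound 2 in one place:

((ethylcarbamoyl)oxy)methyl in place of dimethylcarbamoyl on an aromatic carbon

The leaving group is dimethylcarbamoyl, the entering group ((ethylcarbamoyl)oxy)methyl, on an aromatic carbon of a six-membered aromatic ring of carbon only. Among the measured compounds shown here, no measured pair isolates a change of this kind, so the expectation rests on compound 2 alone. The step from compound 2 to compound 4 is expected to be small in this assay, at most a modest move toward a higher number: a 1.4-fold higher number from compound 2 to compound 4 (0.13 log units; within the scatter). For compound 4 the estimate is 8 nM, with a range from 2.5 nM to 25 nM.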

Compound 4, half-maximal inhibitory concentration: 3.4 nM
Compound 4: middle estimate off by 2.4-fold (0.37 log units), on the high side; measured number inside the range.
By their numbers in this assay, from the lowest: compounds 3, 4 and 2 (each within the scatter of the next); then compound 1.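

Among these compounds, at this position, on an aromatic carbon para to a large group, ((ethylcarbamoyl)oxy)methyl in place of dimethylcarbamoyl gives a 1.7-fold lower number from compound 2 to compound 4 (0.24 log units; within the scatter) in this assay, and this is the only single-place step so far. The exchange therefore leaves the read-out unresolved from that of compound 2, even though the entering group has more heavy atoms and carries a hydrogen-bond donor, while the leaving group has none. Nothing available here bears on the cause of this result.

Still open, as far as these compounds go, is which part of the entering group matters, since the step changes size, donor count and acceptor count at once; a hydroxymethyl group or a primary amide on the same aromatic carbon would begin to separate these features. Also open is how far this position reaches beyond neutral groups, as the compounds shown include no amine or carboxylic acid on this six-membered aromatic ring, and no longer carbamate chain than ethyl.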